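Freeing the Acid: From Methyl Ester to Carboxylic Acid

The source may hold more compounds than are shown below. What is called first, only, known or untested is meant among the compounds shown, and "the series" means these compounds.

Three compounds have been examined in a functional assay on HCT-116 cells (Homo sapiens) for inhibition, read by MTT assay, with a stated time of 72 h; a higher number here means a weaker inhibitor of growth, a lower number a stronger inhibitor of growth:
Compound 1 `CC(C)[C@@H](NC(=O)/C=C/c1ccncc1-c1ccc2ccccc2c1)C(=O)O`: "not determined" (no result reported).
Compound 2 `O=C(O)CCc1ccncc1-c1ccc2ccccc2c1`: a limit of the assay only, > 30000 nM.
Compound 3 `COC(=O)/C=C/c1ccncc1-c1ccc2ccccc2c1`: 350 nM.

For the measured compounds named here, compound 3 therefore stands as the only compound with a real number; compound 1 has no result, and compound 2 sits at the limit of > 30000 nM in this assay, at which 1 of the 3 values shown sits. Compound 4 `O=C(O)/C=C/c1ccncc1-c1ccc2ccccc2c1` differs from compound 3 by hydrogen in place of methyl on an oxygen next to a carbonyl group. Going by the values given here, the single measured step, an at least 85-fold lower number from compound 2 to compound 3 (1.93 log units; beyond the scatter), bears on this change but only in part, since it also swaps a 2-carboxyethyl chain for an ethenyl-linked ester. Because an at least 85-fold lower number from compound 2 to compound 3 (1.93 log units; beyond the scatter) was large, the number for compound 4 is expected to move toward a weaker result, by a 34-fold higher number from compound 3 to compound 4 (1.54 log units; beyond the scatter). Compound 4 is estimated at 12000 nM, within 2000 nM to 40000 nM.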

Compound 4, concentration for 50% growth inhibition: > 30000 nM
Compound 4 was reported as a limit; the forecaster's own chance of this, stated with the estimate: 40%; at least 2.5-fold (0.39 log units) between middle value and limit.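

With the 2-(methoxycarbonyl)ethenyl chain otherwise kept, this isolates the methyl on the ester oxygen: in this assay, hydrogen in its place gives an at least 85-fold higher number from compound 3 to compound 4 (1.93 log units; beyond the scatter). For the compounds shown here, the earlier step had changed the chain as well, so only this pair shows that growth inhibition is lost with this single change. The step between compound 2 and compound 4 cannot be read, and both carboxylic acids rest at a limit of the assay rather than a number: the limit of > 30000 nM in this assay, at which 2 of the 4 values shown sit.

From the compounds shown here alone, it remains open whether an ethyl ester or a primary amide at this place would keep the activity of compound 3.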